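The source may report more compounds than this note shows. Statements on the series, on what has been measured and on what is new or still open speak of the compounds shown alone.

Values so far in an ADME assay on blood (Rattus norvegicus) for metabolic stability, with a stated time of 2 h (on this read-out higher numbers stand for a more stable compound and lower numbers for a less stable compound), are as follows
- compound 1 `CCn1c(CNc2ccccc2)nnc1SCc1nc2cc(C(=O)C(C)C)ccc2o1` gives 42%
- compound 2 `CC/C(=N/O)c1ccc2oc(CSc3nnc(CNc4ccccc4)n3CC)nc2c1` gives 100%

Compound 2 stands highest of the two, with compound 1 lower by a margin beyond the scatter. Compound 3 `CCn1c(CNc2ccccc2)nnc1SCc1nc2cc(Cl)ccc2o1` has not yet been measured. Its change from compound 2 is one chlorine atom in place of a group of 5 heavy atoms (3 carbon, 1 nitrogen, 1 oxygen; no ring), on an aromatic carbon and puts a chloro group on the aromatic carbon that carries the group of 5 heavy atoms in compound 2. Within the data shown here, only one measured step bears on this: a number 58 percentage points higher from compound 1 to compound 2 (beyond the scatter) is large and beyond the scatter, and it exchanges the group that compound 3 loses. Among the measured compounds shown here, no measured compound carries chloro, so that step gives only a rough guide. With compound 2 at 100% as the starting point, a fall is expected in this assay and no rise. The expected change is a number 30 percentage points lower from compound 2 to compound 3 (beyond the scatter) as a moderate estimate beyond the scatter. For compound 3 the estimate is 70% within an expected range of 40% to 100% as the upper end.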

Compound 3, percent of the compound remaining: 92%
The estimate for compound 3 lay 22 percentage points below the measured number; low and high end bracket the measured number.
By their numbers in this assay, from the lowest: compound 1; then compounds 3 and 2 (each within the scatter of the next).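

In this assay, the step of a number 8 percentage points lower from compound 2 to compound 3 (within the scatter) shows that a single chloro group, with no hydrogen-bond donor or acceptor, can stand on this aromatic carbon in place of the group of 5 heavy atoms without a change beyond the scatter. The step of a number 50 percentage points higher from compound 1 to compound 3 (beyond the scatter) gives a second replacement for isopropylcarbonyl with a large gain on the same core, so among these three compounds the low number goes with isopropylcarbonyl alone. No measurement here bears on why these numbers differ.

As far as these compounds go, it remains open whether a smaller carbonyl group such as acetyl on this carbon would also give a low number, and how an amine or a carboxylic acid there would compare with chloro. From the compounds shown here alone, all three compounds share the rest of the core, so the effect of a longer chain elsewhere on it is also open.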